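Hydroquinone to Quinone on the Pyrazole Core

The source may report more compounds than this note shows. Statements on the series, on what has been measured and on what is new or still open speak of the compounds shown alone.

Compound 1 `COc1ccc(OC)c(-c2cc(-c3ccccc3)nn2-c2ccc(S(=O)(=O)NC(C)=O)cc2)c1`, in a functional assay on cells (Cancer cell lines, Homo sapiens) for cytotoxicity, read by sulforhodamine B assay, with a stated time of 48 h (on this read-out lower numbers stand for stronger inhibition of growth and higher numbers for weaker inhibition of growth), compound 1 gives 3740 nM.
Compound 2 `Oc1ccc(O)c(-c2cc(-c3ccccc3)nn2-c2ccccc2)c1`, in this assay compound 2 gives 28500 nM.
Compound 3 `CC(=O)NS(=O)(=O)c1ccc(-n2nc(-c3ccccc3)cc2-c2cc(O)ccc2O)cc1`, in this assay compound 3 gives 78600 nM.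

Compound 3 stands with the highest number of the three. Its nearest neighbour is compound 2, the step being a 2.8-fold higher number from compound 2 to compound 3 (0.44 log units; beyond the scatter), and its furthest is compound 1, with a 21-fold higher number from compound 1 to compound 3 (1.32 log units; beyond the scatter).

Compound 4 `CC(=O)NS(=O)(=O)c1ccc(-n2nc(-c3ccccc3)cc2C2=CC(=O)C=CC2=O)cc1` differs from compound 3 in one place: a group of 8 heavy atoms (6 carbon, 2 oxygen; one six-membered non-aromatic ring of carbon only) in place of a group of 8 heavy atoms (6 carbon, 2 oxygen; one six-membered aromatic ring of carbon only), on an aromatic carbon. Within the data shown here, no measured step makes this same change. Among the measured compounds shown here, the only step that touches the same position is the one from compound 1 to compound 3, which was large; it shows that this position can move the number far, but it exchanges 2,5-dimethoxyphenyl for 2,5-dihydroxyphenyl, not the aromatic ring for the non-aromatic one. The step from compound 2 to compound 3 lies elsewhere and does not bear on it. The expectation for compound 4 is therefore uncertain in direction; a step of the size a 5.2-fold lower number from compound 3 to compound 4 (0.72 log units; beyond the scatter) is estimated, towards a lower number, with a wide range. In this assay compound 4 is expected to give 15000 nM, between 2500 nM and 90000 nM.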

Compound 4, concentration for 50% growth inhibition: 78400 nM
Compound 4: middle estimate off by 5.2-fold (0.72 log units), on the low side, and the stated range covers the measured number.
By their numbers in this assay, from the lowest: compound 1; then compound 2; then compounds 4 and 3 (each within the scatter of the next).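

In this assay, replacing 2,5-dihydroxyphenyl with the group carrying one six-membered non-aromatic ring of carbon only gives a 1.0-fold lower number from compound 3 to compound 4 (0.00 log units; within the scatter), so on this aromatic carbon of the five-membered ring, losing the aromatic ring and going from 2 hydrogen-bond donors to 0 leaves the number unmoved. The earlier compounds had shown only that this position can move the number far, and the new result shows that not every change here does: the large separation remains with 2,5-dimethoxyphenyl, as a 21-fold higher number from compound 1 to compound 4 (1.32 log units; beyond the scatter) sits alongside the step already seen for compound 3. Nothing available explains why these two groups read alike in this assay.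

The compounds shown leave open whether the lower number of compound 1 belongs to the methyl ethers specifically, since no other group on those two oxygens appears, and a 2,5-diethoxyphenyl or a 2,5-diaminophenyl group at this place would help to test that. They also leave open how the non-aromatic ring reads with hydrogen in place of acetylsulfamoyl, or with a carboxylic acid there.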